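Amino in place of hydroxy on the benzyl group: expected potency

This account rests on a few compounds, and the source may have more. Where it says the series, first, only, none or still open, it means among the compounds named here.

Measured compounds:
- compound 1, `COc1ccc(CN(C(=O)CSc2nc3ccccc3s2)c2cc(OC)c(OC)c(OC)c2)cc1C`: 17100 nM
- compound 2, `COc1ccc(CN(C(=O)CSc2nc3ccccc3s2)c2cc(OC)c(OC)c(OC)c2)cc1O`: 182 nM
- compound 3, `COc1cc(N(Cc2ccc(C)cc2)C(=O)CSc2nc3ccccc3s2)cc(OC)c1OC`: > 80000 nM

All three share one core and differ only in the benzyl group on the amide-type nitrogen. In a functional assay on HCT-116 cells (Homo sapiens) for antiproliferative activity, read by MTT assay, with a stated time of 48 h (on this read-out higher numbers stand for weaker inhibition and lower numbers for stronger inhibition), compound 3 gives only a limit, (the limit of > 80000 nM in this assay, at which 1 of the 3 values shown sits), so no number is known for it; it is the weakest of the three shown. Compound 4, `COc1ccc(CN(C(=O)CSc2nc3ccccc3s2)c2cc(OC)c(OC)c(OC)c2)cc1N`, has not yet been tested; it differs from compound 3 by 3-amino-4-methoxyphenyl in place of 4-methylphenyl on a saturated chain carbon bound to an amide-type nitrogen.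

For the measured compounds named here, two measured steps bear on this change. Going the other way, from the 3-hydroxy-4-methoxybenzyl compound to the 4-methylbenzyl compound, cost an at least 430-fold higher number from compound 2 to compound 3 (2.64 log units; beyond the scatter); the smaller change from the 4-methoxy-3-methylbenzyl compound cost an at least 4.6-fold higher number from compound 1 to compound 3 (0.67 log units; beyond the scatter). A group with a hydrogen-bond donor beside the methoxy is therefore expected to give a large step toward a lower number, an at least 53-fold lower number from compound 3 to compound 4 (1.72 log units; beyond the scatter). Compound 4 is accordingly estimated at 1500 nM, between 200 nM and 15000 nM.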

Compound 4, half-maximal inhibitory concentration: 491 nM
The estimate for compound 4 lay 3.1-fold (0.49 log units) above the measured number; measured number inside the range.
By their numbers in this assay, from the lowest: compound 2; then compound 4; then compound 1. At a limit, above all of these: compound 3.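

In this assay, amino in place of hydroxy on this aromatic carbon gives a 2.7-fold higher number from compound 2 to compound 4 (0.43 log units; beyond the scatter) as a modest step, so the swap gives up only a little of the potency. Amino in place of methyl gives a 35-fold lower number from compound 1 to compound 4 (1.54 log units; beyond the scatter) as a large step, which shows that hydroxy is not the only group here that gives a much lower number than methyl. The change from 4-methylbenzyl to 3-amino-4-methoxybenzyl gives an at least 160-fold lower number from compound 3 to compound 4 (2.21 log units; beyond the scatter) as a large step, but its size is only a bound, because compound 3 has only a limit: the limit of > 80000 nM in this assay, at which 1 of the 4 values shown sits.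

The compounds shown leave open how a methylamino, dimethylamino or acetamide group would fare on this carbon. They also leave open whether a fluorine or a carboxylic acid there would keep any of this potency.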